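The source may report more compounds than this note shows. Statements on the series, on what has been measured and on what is new or still open speak of the compounds shown alone.

In a functional assay on A549 cells (Homo sapiens) for cytotoxicity, with a stated time of 48 h (on this read-out higher numbers stand for weaker inhibition of growth and lower numbers for stronger inhibition of growth), the measured compounds are:

- compound 1 `Nc1nc(-c2cc(N3C[C@H](O)[C@@H](O)C3)ccc2O)cc(C2CCCCCC2)n1`: 600 nM
- compound 2 `Nc1nc(-c2cc(N3C[C@H](O)[C@@H](O)C3)ccc2O)cc(C2CCCCC2)n1`: 1200 nM
- compound 3 `CN(C)c1cc(-c2cc(N3C[C@H](O)[C@@H](O)C3)ccc2O)nc(N)n1`: "not determined" (no result reported)

Compound 3 has no place on the scale, since for compound 3 the entry reads "not determined" (no result reported). The step to compound 4 `Nc1nc(-c2cc(N3C[C@H](O)[C@@H](O)C3)ccc2O)cc(C2CCCNC2)n1` is piperidin-3-yl in place of dimethylamino on an aromatic carbon.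

Without a number for compound 3, neither the size nor the direction of this step in this assay can be predicted. Among the measured compounds shown here, the only measured step, a 2.0-fold higher number from compound 1 to compound 2 (0.30 log units; within the scatter), is cyclohexyl in place of cycloheptyl on an aromatic carbon, and it stays within the scatter. It therefore offers only indirect guidance. Any expectation must lean on the two available numbers, compound 1 at 600 nM and compound 2 at 1200 nM, both of which carry a non-aromatic ring on that carbon. With so little support, the expected range has to be wide.

For compound 4 the estimated value is 2000 nM, with an expected range from 500 nM to 10000 nM.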

Compound 4, concentration for 50% growth inhibition: > 10000 nM
Compound 4 was reported as a limit (the forecaster's own chance of this, stated with the estimate: 15%); middle value at least 5.0-fold (0.69 log units) from the limit.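

In this assay, the entry for compound 4 is a limit and not a number: the limit of > 10000 nM in this assay, at which 1 of the 4 values shown sits. Even so, piperidin-3-yl in place of cyclohexyl gives an at least 8.3-fold higher number from compound 2 to compound 4 (0.92 log units; beyond the scatter), and piperidin-3-yl in place of cycloheptyl gives an at least 16-fold higher number from compound 1 to compound 4 (1.22 log units; beyond the scatter). The step from compound 1 to compound 2 had stayed within the scatter, whereas these steps show that growth inhibition in this series can change greatly with the non-aromatic ring at this position, even when the ring stays six-membered and gains a ring nitrogen.

The step from compound 3 to compound 4 cannot be read, as compound 3 has no reported result. On these data alone, it remains open whether a six-membered ring with an oxygen in place of that nitrogen, or a piperidine carrying a methyl on its nitrogen, would keep the values of compound 1 and compound 2 or follow compound 4.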